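This account rests on a few compounds, and the source may have more. Where it says the series, first, only, none or still open, it means among the compounds named here.

Working notes on the series

The series shares one core, varied at the amide group on the amide-type nitrogen. Compound 1 `Cc1cc(N2CC[C@H](N3CCC[C@@H]3C)C2)ccc1NC(=O)C1CCCO1` carries an oxolan-2-yl group on the carbonyl carbon; in an assay on CHO cells for displacement of a labelled ligand from histamine receptor H3 (Macaca mulatta) (a higher number here means a weaker inhibitor, a lower number a stronger inhibitor), compound 1 gives 7.33 nM. Compound 2 `Cc1cc(NC(=O)CC2CCCC2)ccc1N1CCC(N2CCCC2C)C1` carries a cyclopentyl-bearing chain in the same region and in this assay compound 2 gives 10.7 nM. The two numbers lie within the usual scatter of each other, so neither compound can be set apart from the other on these data.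

Compound 3 `Cc1cc(N2CC[C@H](N3CCC[C@@H]3C)C2)ccc1NC(=O)C1CC2CCC1C2` is the next member. It differs from compound 1 in one place: a group of 7 heavy atoms (7 carbon; 2 five-membered non-aromatic rings of carbon only) in place of a group of 5 heavy atoms (4 carbon, 1 oxygen; one five-membered non-aromatic ring with 1 hetero atom), on a carbonyl carbon. The entering group keeps the ring count at the carbonyl carbon but removes the single hydrogen-bond acceptor that the oxolan-2-yl group supplies. Among the measured compounds shown here, no measured pair isolates such a change, so there is no step to lean on. Given that compound 1 gives 7.33 nM in this assay, compound 3 is expected to land close by, with the step from compound 1 to compound 3 estimated at a 1.2-fold higher number from compound 1 to compound 3 (0.09 log units; within the scatter), that is, no more than the scatter in either direction. The estimate for compound 3 in this assay is 9 nM, with a range from 3 nM to 30 nM.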

Compound 3, inhibition constant: 0.55 nM
Compound 3: middle estimate off by 16-fold (1.21 log units), on the high side; the measured number lies below the stated range.
By their numbers in this assay, from the lowest: compound 3; then compounds 1 and 2 (each within the scatter of the next).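

In this assay, among the compounds shown here, the group on the carbonyl carbon proves able to move the number well beyond the scatter: replacing oxolan-2-yl with the all-carbon group of 7 heavy atoms and 2 five-membered non-aromatic rings gives a 13-fold lower number from compound 1 to compound 3 (1.12 log units; beyond the scatter), which the earlier compounds, with values within the scatter of each other, did not reveal. This one exchange combines two differences, the loss of the hydrogen-bond acceptor of the oxolan-2-yl group and the change to an all-carbon group with more heavy atoms and a second ring, and this single pair cannot separate them. No measurement at hand addresses the origin of this step.

Going by these compounds, it remains open whether the missing ring oxygen or the added carbon framework accounts for the step, a question that a plain cyclopentyl or a cyclohexyl group on the same carbonyl carbon of the core of compound 1 would address. On these data alone, the effect on the number of an amine or a carboxylic acid carried on the all-carbon group of compound 3 also remains open.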